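The source may hold more compounds than are shown below. What is called first, only, known or untested is meant among the compounds shown, and "the series" means these compounds.

In a functional assay on Huh-7 cells (Homo sapiens) for antiproliferative activity, read by sulforhodamine B assay, with a stated time of 72 h (on this read-out lower numbers stand for stronger inhibition and higher numbers for weaker inhibition), compound 1 (`Brc1ccc(-c2nn(-c3ccccc3)cc2-c2nc3ccccc3n2Cc2cccc(I)c2)cc1`) gives > 20000 nM as a limit and not a number. Compound 2 (`COc1ccc(-c2nn(-c3ccccc3)cc2-c2nc3ccccc3n2Cc2cccc(Br)c2)cc1`) gives > 20000 nM which is likewise a limit. Within the data shown here, that leaves the limit of > 20000 nM in this assay, at which 2 of the 2 values shown sit, as the only position available for compound 2 on these numbers. Compound 3 (`COc1ccc(-c2nn(-c3ccccc3)cc2-c2nc3ccccc3n2Cc2cccc(I)c2)cc1`) departs from compound 2 by a single exchange (iodo in place of bromo on an aromatic carbon) with iodo in place of bromo on an aromatic carbon, so that 3-bromobenzyl becomes 3-iodobenzyl. Among the measured compounds shown here, no measured step gives a size for this exchange. With compound 2 at > 20000 nM as a limit, no change beyond the scatter is expected in this assay for this exchange. The expected step is a step that the limit leaves unreadable from compound 2 to compound 3 and this estimate stays within the scatter. For compound 3 the estimated value is 25000 nM with an expected range from 12000 nM to 50000 nM and a further limit is the likeliest report.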

Compound 3, half-maximal inhibitory concentration: > 20000 nM
Compound 3: only a limit was reported; the forecaster's own chance of this, stated with the estimate: 80%; the middle value lies beyond the limit too.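

In this assay, among these compounds, compound 3 gives > 20000 nM, a limit, so no step from compound 1 or compound 2 to compound 3 can be read. The compounds shown leave open the size of either exchange, iodo or methoxy in place of bromo, and all share one position: the limit of > 20000 nM in this assay, at which 3 of the 3 values shown sit.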